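Swapping phenoxy for dimethylamino on a cytotoxicity screen

The source may report more compounds than this note shows. Statements on the series, on what has been measured and on what is new or still open speak of the compounds shown alone.

Of the compounds shown here, three with a shared core have been measured so far. Compound 1 `COc1cc(C)cc(-c2c(-c3ccnc(-c4ccc(C(C)=O)cc4)c3)cnn2CC#N)c1` gives 102% in a functional assay on MOLT-4 cells (Homo sapiens) for cytotoxicity, read by sulforhodamine B assay, with a stated time of 48 h, tested at 0.001 uM; a lower number here means a stronger effect, a higher number a weaker effect of the compound at the concentration tested. Compound 2 `COc1cc(C)cc(-c2nn(CC#N)cc2-c2ccc(-c3cccc(C(C)=O)c3)nc2)c1` gives 97% in this assay. Compound 3 `Cc1cc(O)cc(-c2nn(CC#N)cc2-c2ccnc(-c3ccc(Oc4ccccc4)cc3)c2)c1` gives 99% in this assay. All three numbers sit close to one another: compound 3 stands between the other two, with compound 2 the nearest and compound 1 the furthest, and both of those gaps lie within the usual scatter of repeated measurements. At the very low concentration tested, none of the three shows a read-out that departs clearly from the untreated level.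

Compound 4 `Cc1cc(O)cc(-c2nn(CC#N)cc2-c2ccnc(-c3ccc(N(C)C)cc3)c2)c1` has not yet been measured. It differs from compound 3 in one place: dimethylamino in place of phenoxy on an aromatic carbon.

For the measured compounds named here, no step between two measured compounds is available to guide an expectation, so the estimate rests on the fact that every measured value here lies at or near the same level. On that basis the step of no change at the digits printed from compound 3 to compound 4 (within the scatter) in this assay is expected to be none beyond the scatter. Compound 4 is accordingly estimated at 99%, with a plausible range from 90% to 108%.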

Compound 4, a percentage reported as activity, at one concentration (the size of the read-out at that concentration, not a potency): 100%
Compound 4: the middle estimate sits 1 percentage points below what was measured; the range from low to high includes it.
By their numbers in this assay, from the lowest: compounds 2, 3, 4 and 1 (each within the scatter of the next).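

For the compounds shown here, the step of a number 1 percentage points higher from compound 3 to compound 4 (within the scatter) in this assay is the first direct comparison of two compounds that differ in only one place, with dimethylamino in place of phenoxy on an aromatic carbon, para to a large group. The change is a sizeable one in structure: phenoxy brings 7 heavy atoms and a six-membered aromatic ring of carbon only, whereas dimethylamino brings 3 heavy atoms and no ring, yet each carries 1 hydrogen-bond acceptor and no net charge. Even so, at this one very low concentration the read-out does not separate the two compounds, and no measurement here bears on the reason for that result.

A read-out this close to the untreated level cannot show whether the two groups would differ at a concentration where the compounds have a clear effect, so this result does not establish that the position tolerates any change. It also leaves open how a group of a different kind on the same aromatic carbon, such as a carboxylic acid or a primary amine, would behave in this assay.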